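The source may report more compounds than this note shows. Statements on the series, on what has been measured and on what is new or still open speak of the compounds shown alone.

Compounds measured so far:
- Compound 1 `C=C(Br)C(=O)Nc1ccc(/C=C/C(=O)c2ccccc2)cc1`: 3900 nM
- Compound 2 `C=C(Br)C(=O)Nc1ccc(/C=C/C(=O)c2ccc(C)cc2)cc1`: 2100 nM

Both values come from a functional assay on FM3A cells (Mus musculus) for antiproliferative activity, with a stated time of 48 h; on this read-out lower numbers stand for stronger inhibition and higher numbers for weaker inhibition. Compound 2 has the smaller number of the pair, but the two values lie within the scatter of each other, so the data do not rank it ahead of compound 1.

The next compound is compound 3 `C=C(Br)C(=O)Nc1ccc(/C=C/C(=O)c2cccc(OC)c2)cc1`, which has 3-methoxyphenyl in place of 4-methylphenyl on a carbonyl carbon. Among the compounds with values here, the only measured step that bears on this change is methyl in place of hydrogen on an aromatic carbon, a 1.9-fold lower number from compound 1 to compound 2 (0.27 log units; within the scatter). Within the data shown here, that step stayed within the scatter, but it is a single, different exchange, and no measured compound carries a methoxy group. It therefore offers only weak guidance, and no shift beyond the scatter is expected in this assay, in either direction. The expected change is a 1.2-fold higher number from compound 2 to compound 3 (0.08 log units; within the scatter). For compound 3 the estimated value is 2500 nM, with an expected range from 900 nM to 7000 nM.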

Compound 3, half-maximal inhibitory concentration: 2700 nM
Estimate against measurement, compound 3: 1.1-fold (0.03 log units) below; low and high end bracket the measured number.
By their numbers in this assay, from the lowest: compounds 2, 3 and 1 (each within the scatter of the next).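

In this assay, 3-methoxyphenyl in place of 4-methylphenyl on a carbonyl carbon gives a 1.3-fold higher number from compound 2 to compound 3 (0.11 log units; within the scatter), and the exchange that adds a methoxy group to the aromatic ring gives a 1.4-fold lower number from compound 1 to compound 3 (0.16 log units; within the scatter). The first exchange brings in a group with 1 hydrogen-bond acceptor in place of one with 0 and also changes the ring carbon that carries the added group, yet the result stays within the scatter, as does the second exchange, so this aromatic ring has now taken both a methyl and a methoxy group without a separation from compound 1 beyond the scatter. No supporting measurement bears on this result, so the values stand here without an explanation.

The compounds shown leave open whether any group on this ring can move the number beyond the scatter, since an amine, a carboxylic acid or a halogen such as chlorine does not appear among them. They also cannot separate the change of group from the change of ring carbon in the exchange from compound 2 to compound 3, a question that 4-methoxyphenyl would address.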